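Ring Size at the Amine: Pyrrolidine to Piperidine

The source may report more compounds than this note shows. Statements on the series, on what has been measured and on what is new or still open speak of the compounds shown alone.

Compound 1 `N#C/C(=C\c1ccc(Br)cc1)C(=O)O`: 500 nM
Compound 2 `N#C/C(=C\c1ccc(N2CCCC2)cc1)C(=O)O`: 70 nM

For the measured compounds named here, in an assay on RBE4 cells for inhibition of Monocarboxylate transporter 1 (Rattus norvegicus), with a stated time of 15 min (on this read-out higher numbers stand for weaker inhibition and lower numbers for stronger inhibition), compound 2 gives the lowest of these two numbers; compound 1 is the only neighbour, and the single measured step, a 7.1-fold lower number from compound 1 to compound 2 (0.85 log units; beyond the scatter), is what set compound 2 apart. Compound 3 `N#C/C(=C\c1ccc(N2CCCCC2)cc1)C(=O)O` differs from compound 2 by piperidin-1-yl in place of pyrrolidin-1-yl on an aromatic carbon. Going by the values given here, no measured step exchanges one ring amine for another; the one step on record swapped a halogen for the ring amine and says little about ring size. A step within the scatter is therefore expected, in either direction. Compound 3 is estimated at 70 nM, between 25 nM and 200 nM, which would mean no change at the digits printed from compound 2 to compound 3 (within the scatter).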

Compound 3, half-maximal inhibitory concentration: 140 nM
For compound 3 the middle estimate is 2.0-fold (0.30 log units) below the measured one; measured number inside the range.
By their numbers in this assay, from the lowest: compounds 2 and 3 (each within the scatter of the next); then compound 1.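

The ring amine on this aromatic carbon can be five- or six-membered without leaving the scatter, with a 2.0-fold higher number from compound 2 to compound 3 (0.30 log units; within the scatter) in this assay. The advantage over bromo is also not confined to pyrrolidin-1-yl, since piperidin-1-yl in place of bromo gives a 3.6-fold lower number from compound 1 to compound 3 (0.55 log units; beyond the scatter). No supporting data bear on what lies behind these steps. Still open, from the compounds shown here alone, is how a ring amine with a second hetero atom, such as morpholin-4-yl, or an open-chain amine, such as dimethylamino, would read at this position.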